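This account rests on a few compounds, and the source may have more. Where it says the series, first, only, none or still open, it means among the compounds named here.

Of the compounds shown here, two have been measured in a functional assay on the whole organism (strain Wistar albino) for inhibition, with Rattus norvegicus as the target, read by paw edema, with a stated time of 1 h, at a dose of 25 mg/kg by the oral route; a higher number here means more inhibition at the dose given (going by the name of the read-out), a lower number less inhibition. Compound 1 `CSc1nn(-c2ccccc2)c2nc(Nc3ccccc3)n(-c3ccccc3)c(=O)c12` gives 46.1%, and compound 2 `O=c1c2c(Nc3ccc([N+](=O)[O-])cc3)nn(-c3ccccc3)c2nc(Nc2ccccc2)n1-c1ccccc1` gives 29.4%. Within the data shown here, the one step between them, a number 16.7 percentage points lower from compound 1 to compound 2 (beyond the scatter), came with (4-nitrophenyl)amino in place of methylsulfanyl on an aromatic carbon. Compound 2 thus stands lowest of the two numbers, with compound 1 as its nearest neighbour, higher by a step beyond the scatter.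

Compound 3 `Cc1ccc(Nc2nn(-c3ccccc3)c3nc(Nc4ccccc4)n(-c4ccccc4)c(=O)c23)cc1` has not yet been measured. It differs from compound 2 in one place: methyl in place of nitro on an aromatic carbon. Among the measured compounds shown here, no measured step matches this change; the only step known, from compound 1 to compound 2, exchanged methylsulfanyl for the whole (4-nitrophenyl)amino group and so says little about what the nitro alone contributes. With (4-methylphenyl)amino now standing where (4-nitrophenyl)amino stood, the expected step of a number 6.6 percentage points higher from compound 2 to compound 3 (within the scatter) is small, and it may well fall within the scatter. Because compound 2, the compound bearing the nitro, gave 29.4%, the lower of the two, a modest rise rather than a further fall is the more plausible expectation, though nothing measured compels it. Compound 3 is therefore estimated to give 36%, within a range of 24% to 48%.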

Compound 3, a percentage reported as inhibition, in the whole organism at one dose (the size of the read-out at that dose, not a potency): 55.7%
Compound 3: the middle estimate sits 19.7 percentage points below what was measured, outside the stated range (above it).
By their numbers in this assay, from the lowest: compound 2; then compounds 1 and 3 (each within the scatter of the next).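

In this assay, methyl in place of nitro on the six-membered aromatic ring came with a number 26.3 percentage points higher from compound 2 to compound 3 (beyond the scatter), so the group at this one place, para to a large group, matters on its own, apart from the rest of the (4-nitrophenyl)amino substituent. The earlier fall on going from methylsulfanyl to (4-nitrophenyl)amino therefore cannot be read as a penalty for any arylamino group at that carbon of the core: (4-methylphenyl)amino in place of methylsulfanyl gave a number 9.6 percentage points higher from compound 1 to compound 3 (within the scatter), which leaves these two groups apart by no more than the usual spread of this read-out. Nothing given here bears on the reason that nitro and methyl part in this way.

Going by these compounds, with only nitro and methyl to compare at this place on the ring, it remains open whether a methoxy group, a chlorine atom or plain hydrogen would follow compound 3 or compound 2. Also open, on these data alone, is how a saturated cyclic amine such as morpholine would fare in place of the whole arylamino group on the same carbon of the core.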